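Swapping a Spiro Cyclopropane for a Spiro Cyclopentane

The source may hold more compounds than are shown below. What is called first, only, known or untested is meant among the compounds shown, and "the series" means these compounds.

Compound 1 `COc1ccc2[nH]c(C(=O)N3CC(=O)N(Cc4ccccc4)[C@@H](CCN4CCC5(CC4)CC5)C3)cc2c1` was tested in a physicochemical assay for solubility, read by spectrophotometry, in phosphate buffer, with a stated time of 2 h, at pH 7.4 (on this read-out higher numbers stand for higher solubility and lower numbers for lower solubility), where it reaches only a limit of the assay, > 25000 nM. This places compound 1 at the limit of > 25000 nM in this assay, at which 1 of the 2 values shown sits. Compound 2 `COc1ccc2[nH]c(C(=O)N3CC(=O)N(Cc4cccc(OC(F)F)c4)[C@@H](CN4CCN(C5CC5)CC4)C3)cc2c1` gives 99600 nM in this assay. Compound 3 `COc1ccc2[nH]c(C(=O)N3CC(=O)N(Cc4ccccc4)[C@@H](CN4CCC5(CCCC5)CC4)C3)cc2c1` differs from compound 1 by a group of 10 heavy atoms (9 carbon, 1 nitrogen; one five-membered non-aromatic ring of carbon only, one six-membered non-aromatic ring with 1 hetero atom) in place of a group of 9 heavy atoms (8 carbon, 1 nitrogen; one three-membered non-aromatic ring of carbon only, one six-membered non-aromatic ring with 1 hetero atom), on a saturated chain carbon bound to a saturated ring carbon. Among the compounds with values here, no measured pair carries this exact change, so its size is not known from the data; a modest drop beyond the usual scatter is expected, as an at least 1.2-fold lower number from compound 1 to compound 3 (0.09 log units; that floor lies within the scatter). Compound 3 is therefore estimated to show 20000 nM, most likely between 5000 nM and 60000 nM.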

Compound 3, solubility: 5000 nM
For compound 3 the middle estimate is 4.0-fold (0.60 log units) above the measured one; the range from low to high includes it.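

In this assay, putting the group with the five-membered carbon ring in place of the group with the three-membered carbon ring, on a saturated chain carbon bound to a saturated ring carbon, gives an at least 5.0-fold lower number from compound 1 to compound 3 (0.69 log units; beyond the scatter). This position therefore responds to the ring it carries, a point no earlier comparison could show. Compound 1 reaches only a limit, so this step is a minimum, not an exact size: the limit of > 25000 nM in this assay, at which 1 of the 3 values shown sits. On these data alone, what a four-membered carbon ring or a hydroxyl group on the ring would do at this place stays open.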